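The source may report more compounds than this note shows. Statements on the series, on what has been measured and on what is new or still open speak of the compounds shown alone.

Measured compounds:

Compound 1, `C[C@H](Nc1nc(N)ncc1C#N)c1cc2ccc(F)cn2c(=O)c1-c1ccccc1`, in an ADME assay on microsomes from liver (Mus musculus), read by LC-MS, using NADPH, with a stated time of 30 min, tested at 1 uM (on this read-out higher numbers stand for a more stable compound and lower numbers for a less stable compound), compound 1 gives 11%.
Compound 2, `Cc1c([C@H](C)Nc2ncnc(N)c2C#N)c(-c2ccc(F)cc2)c2ccc(F)cn2c1=O`, in this assay compound 2 gives "not determined" (no result reported).
Compound 3, `Cc1c([C@H](C)Nc2nc(N)nc(N)c2C#N)c(-c2ccccc2)c(=O)n2cc(F)ccc12`, in this assay compound 3 gives 85%.

Of the two compounds with a number, compound 3 stands highest, and its gap to compound 1 lies well beyond the usual scatter of repeated measurements. Compound 2 adds no number to the comparison.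

The next compound, compound 4, `C[C@H](Nc1nc(N)nc(N)c1C#N)c1c(-c2ccccc2)c(=O)n2cc(F)ccc2c1-c1ccc(F)cc1`, is built from compound 3 by a single change: 4-fluorophenyl in place of methyl on an aromatic carbon. In words, a 4-fluorophenyl takes the place of a methyl on an aromatic carbon of the shared core. Among the compounds with values here, no measured pair in this set shows what such an exchange does in this assay, so the size of the step can only be guessed. Compound 3 sits high, and a loss of some size is thought more likely than a gain, though a step within the scatter cannot be excluded. Compound 4 is therefore expected to give about 55%, somewhere in the range 20% to 90%. This estimate amounts to a step of a number 30 percentage points lower from compound 3 to compound 4 (beyond the scatter).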

Compound 4, percent of the compound remaining: 83%
For compound 4 the middle estimate is 28 percentage points below the measured one, and the stated range covers the measured number.
By their numbers in this assay, from the lowest: compound 1; then compounds 4 and 3 (each within the scatter of the next).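

Placing 4-fluorophenyl in place of methyl on this aromatic carbon of the shared core gives in this assay the result a number 2 percentage points lower from compound 3 to compound 4 (within the scatter) and so shows no difference that stands out from the usual scatter. Within the data shown here, this pair is the first to show that this position can carry a whole aromatic ring instead of a single methyl carbon with the percent remaining staying in the same range. Nothing available here explains why the two groups read alike.

Among these compounds, only this one exchange at this position can be read, so it stays open whether a carboxylic acid, an amine or a longer chain such as butyl would leave the read-out equally unmoved. As far as these compounds go, whether 4-fluorophenyl would behave the same way on a different core also stays open.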